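The source may report more compounds than this note shows. Statements on the series, on what has been measured and on what is new or still open speak of the compounds shown alone.

Compound 1 `CC(C)Oc1ccccc1OC(C)C1=NCCN1`: 0.7 in an assay on CHO cells with Alpha-2C adrenergic receptor (Homo sapiens) as the target; on this read-out higher numbers stand for larger maximal responses and lower numbers for smaller maximal responses
Compound 2 `CC(Oc1ccccc1Br)C1=NCCN1`: 0.87 in this assay

Of these two numbers, compound 2 stands highest; its nearest neighbour is compound 1, whose value is lower by a gap beyond the scatter. Going by the values given here, the one measured step, a number 0.17 higher from compound 1 to compound 2 (beyond the scatter), shows that changing the group on this aromatic carbon can shift the maximal response by a modest amount. Compound 3 `CC(=O)c1ccccc1OC(C)C1=NCCN1` is not yet measured. Its change from compound 2 is acetyl in place of bromo on an aromatic carbon. No measured step exchanges bromo for acetyl, so the direction of this change is not directly shown. Compound 2 carries the higher value 0.87, and acetyl resembles neither of the two measured groups, which leaves room mainly for a small move downward. The expected step, a number 0.12 lower from compound 2 to compound 3 (beyond the scatter), is therefore a modest fall, possibly within the scatter. Compound 3 is estimated at 0.75, between 0.5 and 0.95.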

Compound 3, intrinsic activity: the largest response reached, as a fraction of the reference agonist's: 0.65
Compound 3: the middle estimate sits 0.10 above what was measured; measured number inside the range.
By their numbers in this assay, from the lowest: compounds 3 and 1 (each within the scatter of the next); then compound 2.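

Acetyl in place of bromo on this aromatic carbon gives a number 0.22 lower from compound 2 to compound 3 (beyond the scatter) in this assay and so adds a second group that sits clearly under bromo. Acetyl in place of isopropoxy gives a number 0.050 lower from compound 1 to compound 3 (within the scatter) and leaves these two groups indistinguishable on this read-out. Among the three groups at this position, only bromo therefore stands apart, even though acetyl and isopropoxy are different groups; acetyl, for instance, brings a hydrogen-bond acceptor and a double bond outside the aromatic ring.

From the compounds shown here alone, whether the higher maximal response is special to bromo or would also appear with chloro, fluoro or a plain methyl group at this carbon remains open. The data shown offer no measurement that explains why the response shifts with these groups.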